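Bromo on the sulfonyl phenyl of compound 1

A few compounds are considered here, and "the series" means these few. Any claim that something is new, unique, unknown or untested is made for them only; others in the source may bear on it.

Among the measured compounds shown here, in a functional assay on HCT-116 cells (Homo sapiens) for cytotoxicity, read by MTT assay, with a stated time of 72 h (on this read-out lower numbers stand for stronger inhibition and higher numbers for weaker inhibition), compound 1 `COc1cc(Nc2nc3ccccc3nc2S(=O)(=O)c2ccccc2)cc(OC)c1` gives 950 nM, the lowest of the two numbers so far. Compound 2 `O=S(=O)(c1ccccc1)c1nc2ccccc2nc1Nc1ccc(F)cc1` gives 5190 nM, and the step of a 5.5-fold higher number from compound 1 to compound 2 (0.74 log units; beyond the scatter) swaps the aryl on the nitrogen on the aromatic ring. Compound 3 `COc1cc(Nc2nc3ccccc3nc2S(=O)(=O)c2ccc(Br)cc2)cc(OC)c1` differs from compound 1 by bromo in place of hydrogen on an aromatic carbon, on the phenylsulfonyl side. No measured step touches that ring, so nothing shown bears on this change; with no guide, no step beyond the scatter is expected in this assay. Compound 3 is therefore estimated at 900 nM, within 300 nM to 3000 nM, an expected step of a 1.1-fold lower number from compound 1 to compound 3 (0.02 log units; within the scatter).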

Compound 3, half-maximal inhibitory concentration: > 50000 nM
Compound 3: a limit, no number (the forecaster's own chance of this, stated with the estimate: 3%); middle value at least 55-fold (1.74 log units) away from the limit.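

Among the compounds shown here, the phenylsulfonyl side, untouched by the earlier compounds, is not silent in this assay: bromo in place of hydrogen, para to a large group, gives an at least 52-fold higher number from compound 1 to compound 3 (1.72 log units; beyond the scatter). One heavy atom on this ring is enough to take the series out of the measured range. Compound 3 stands as a limit, not a number: the limit of > 50000 nM in this assay, at which 1 of the 3 values shown sits.

Whether this step belongs to bromo itself or to any group at this place stays open, with only one group shown on this ring. Fluoro, an amine or a carboxylic acid at the same place would separate these two readings.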